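Pyridinylmethylamine in place of dimethylamine on the shared core

The source may hold more compounds than are shown below. What is called first, only, known or untested is meant among the compounds shown, and "the series" means these compounds.

Measured compounds:
compound 1 `COc1cccc(-c2c(C)n(Cc3ccccc3F)c3nc(C(C)(C)C)c(CN(C)C)n3c2=O)c1` 1700 nM
compound 2 `COC(=O)C(C)(C)c1nc2n(Cc3ccccc3F)c(C)c(-c3cccc(OC)c3)c(=O)n2c1CN(C)Cc1ccccn1` 4.2 nM
compound 3 `COC(=O)C(C)(C)c1nc2n(Cc3ccccc3F)c(C)c(-c3cccc(OC)c3)c(=O)n2c1CN1CCC(c2ccccc2)CC1` 5100 nM

In an assay on isolated protein for binding affinity to Gonadotropin-releasing hormone receptor (Homo sapiens) (a higher number here means a weaker inhibitor, a lower number a stronger inhibitor), compound 1 stands second highest of the three numbers, nearest to compound 3 and far from compound 2. The unmeasured compound 4 `COc1cccc(-c2c(C)n(Cc3ccccc3F)c3nc(C(C)(C)C)c(CNCc4ccccn4)n3c2=O)c1` differs from compound 1 by ((pyridin-2-yl)methyl)amino in place of dimethylamino on a saturated chain carbon bound to an aromatic carbon. Within the data shown here, no measured pair carries this exact change. The step of a 1200-fold higher number from compound 2 to compound 3 (3.08 log units; beyond the scatter) shows that the amine on that chain carbon can move this assay by a large amount, and compound 2, which carries a pyridin-2-ylmethyl amine, sits far below compound 1. A large step downward is therefore expected for compound 4, a 57-fold lower number from compound 1 to compound 4 (1.75 log units; beyond the scatter). Compound 4 is estimated at 30 nM, within 5 nM to 200 nM.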

Compound 4, inhibition constant: 30 nM
For compound 4 middle estimate and measured number coincide at the digits printed; low and high end bracket the measured number.
By their numbers in this assay, from the lowest: compound 2; then compound 4; then compound 1; then compound 3.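

In this assay, among these compounds, the first direct reading of this change on the core of compound 1 is a large gain (a 57-fold lower number from compound 1 to compound 4 (1.75 log units; beyond the scatter)). The amine on the saturated chain carbon bound to an aromatic carbon therefore governs the number on this core too, as it does in the other pair (a 1200-fold higher number from compound 2 to compound 3 (3.08 log units; beyond the scatter)). No available evidence explains the size of the step.

The entering group changes the ring, the amine hydrogen and the size together, so their shares remain unresolved. A benzylamine, or the same pyridin-2-ylmethyl amine carrying a methyl on its nitrogen, would separate them.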